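Trading a diol for a ring on the ester

The source may report more compounds than this note shows. Statements on the series, on what has been measured and on what is new or still open speak of the compounds shown alone.

In a physicochemical assay for solubility, read by nephelometry, measured as kinetic solubility (on this read-out lower numbers stand for lower solubility and higher numbers for higher solubility), compound 3 (`CCC/N=C1\S/C(=C\c2ccc(C(=O)OCC(O)CO)cc2)C(=O)N1c1ccccc1O`) gives > 250000 nM, which is a limit of the assay and not a number. Compound 3 therefore stands at the limit of > 250000 nM in this assay, at which 1 of the 3 values shown sits.

Compound 2 (`CCC/N=C1\S/C(=C\c2ccc(C(=O)OCCCO)cc2)C(=O)N1c1ccccc1O`) reads 183000 nM in this assay. The step to its closest relative is an at least 1.3-fold higher number from compound 2 to compound 3 (0.13 log units; that floor lies within the scatter), and it comes from a single added hydroxy on the ester chain. Within the data shown here, that is the only measured step on this chain, and it gives no firm size for a larger swap.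

Compound 4 (`CCC/N=C1\S/C(=C\c2ccc(C(=O)OCc3oc(=O)oc3C)cc2)C(=O)N1c1ccccc1O`) keeps the shared core and changes only at the end of the ester chain, where the 1,2-dihydroxyethyl group leaves: a group of 7 heavy atoms (4 carbon, 3 oxygen; one five-membered aromatic ring with 2 hetero atoms) in place of a group of 4 heavy atoms (2 carbon, 2 oxygen; no ring), on a saturated chain carbon bound to an oxygen next to a carbonyl group. Among the measured compounds shown here, no measured step replaces a chain with a ring, so the nearest guide is a plain value. Compound 1 (`CCC/N=C1\S/C(=C\c2ccc(C(=O)OC)c(Cl)c2)C(=O)N1c1ccccc1C`), which has no hydroxy on its ester chain but also differs elsewhere, reads 39000 nM.

Compound 4 has no hydroxy on that chain either, so a fall beyond the scatter is expected in this assay. The expected change is an at least 4.1-fold lower number from compound 3 to compound 4 (0.61 log units; beyond the scatter). For compound 4 the estimated value is 60000 nM, with an expected range of 20000 nM to 150000 nM.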

Compound 4, solubility: 79000 nM
Compound 4: middle estimate off by 1.3-fold (0.12 log units), on the low side, within the range that was stated.
By their numbers in this assay, from the lowest: compound 1; then compound 4; then compound 2. At a limit, above all of these: compound 3.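

In this assay, placing the group with one five-membered aromatic ring with 2 hetero atoms on the saturated chain carbon, where the 1,2-dihydroxyethyl group stood, gives an at least 3.1-fold lower number from compound 3 to compound 4 (0.50 log units; beyond the scatter). Among these compounds, compound 3 stands at a limit of the assay and not at a number, so this step sets only a floor on the change: the limit of > 250000 nM in this assay, at which 1 of the 4 values shown sits. Measured against the open chain with a single hydroxy, the same ring-bearing group gives a 2.3-fold lower number from compound 2 to compound 4 (0.36 log units; beyond the scatter), which shows for the first time what replacing a chain with a ring does at this place: the number falls beyond the scatter, and the fall from the better-defined starting point is modest.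

The change removes the hydroxy groups and adds the ring in a single move, so the compounds shown cannot tell how much of the fall belongs to each. A ring carrying a hydroxy, an amine or a carboxylic acid on the same ester chain would be needed to pull those two parts apart.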